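Swapping the Acid Side Group for an Amide

A few compounds are considered here, and "the series" means these few. Any claim that something is new, unique, unknown or untested is made for them only; others in the source may bear on it.

Measured compounds: compound 1 `CC(C)C[C@@H]1NC(=O)[C@H](CS)NC1=O` with 88.9%, compound 2 `CC(C)C[C@@H]1NC(=O)[C@H](Cc2cnc[nH]2)NC1=O` with 83.9%, compound 3 `CC(C)C[C@@H]1NC(=O)[C@H](CCC(=O)O)NC1=O` with 97.8%, all in a functional assay, tested at 2.5 mM; a lower number here means less inhibition, a higher number more inhibition at the concentration tested (going by the name of the read-out).

Compound 3 gives the highest number of the three. Against compound 1 the gap is within the scatter, while against compound 2 the step of a number 13.9 percentage points higher from compound 2 to compound 3 (beyond the scatter) stands beyond it. Compound 4 `CC(C)C[C@@H]1NC(=O)[C@H](CC(N)=O)NC1=O` changes only the side group: carbamoyl in place of carboxymethyl on a saturated chain carbon bound to a saturated ring carbon. The measured steps that bear on it are those into compound 3, a number 8.9 percentage points higher from compound 1 to compound 3 (within the scatter) and a number 13.9 percentage points higher from compound 2 to compound 3 (beyond the scatter), both exchanges at the same place and both small or modest. A modest drop is therefore expected for compound 4, a number 7.8 percentage points lower from compound 3 to compound 4 (within the scatter). Compound 4 is estimated at 90%, between 78% and 99%.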

Compound 4, a percentage reported as inhibition, at one concentration (the size of the read-out at that concentration, not a potency): 96%
The estimate for compound 4 lay 6 percentage points below the measured number; the range from low to high includes it.
By their numbers in this assay, from the lowest: compounds 2, 1, 4 and 3 (each within the scatter of the next, the first and the last beyond it).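

In this assay carbamoyl in place of carboxymethyl on this saturated chain carbon leaves the reading within the scatter (a number 1.8 percentage points lower from compound 3 to compound 4 (within the scatter)), so a reading of this size does not require the carboxylic acid. The gap to the imidazole side group also remains without the acid (a number 12.1 percentage points higher from compound 2 to compound 4 (beyond the scatter)), while the sulfanyl compound stays within the scatter (a number 7.1 percentage points higher from compound 1 to compound 4 (within the scatter)). Nothing measured here explains these results.

On these data alone, whether an amine, a methyl ester or a longer chain ending in the amide would hold the reading at this place stays open. Readings at one concentration also leave potency open.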